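Ester tail variation and microsomal half-life

The source may report more compounds than this note shows. Statements on the series, on what has been measured and on what is new or still open speak of the compounds shown alone.

Working notes. Within the data shown here, compound 3 `CCOc1cc(NC(=O)C2(NC(=O)c3ccc4c(C5CCCC5)c(-c5ncc(Cl)cn5)n(C)c4c3)CCC2)ccc1/C=C/C(=O)OCCOCCOC` is the one member of the series with a numerical read-out in an ADME assay (liver) for pharmacokinetics, with Liver microsome (Homo sapiens) as the target, using microsomes; on this read-out lower numbers stand for a shorter-lived compound and higher numbers for a longer-lived compound: compound 3 gives 0.85 h. Compound 1 `CCOC(=O)/C=C/c1ccc(NC(=O)C2(NC(=O)c3ccc4c(C5CCCC5)c(-c5ncc(Cl)cn5)n(C)c4c3)CCC2)cc1OCC` reaches only a limit of the assay in this assay, namely > 5 h. Compound 2 `CCOc1cc(NC(=O)C2(NC(=O)c3ccc4c(C5CCCC5)c(-c5ncc(Cl)cn5)n(C)c4c3)CCC2)ccc1/C=C/C(=O)OCc1ccccc1` likewise sits at a limit of the assay in this assay, namely > 5 h. Compound 3 therefore holds the shortest half-life among the three values shown, the other two standing at the limit of > 5 h in this assay, at which 2 of the 3 values shown sit.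

Compound 4 `CCOc1cc(NC(=O)C2(NC(=O)c3ccc4c(C5CCCC5)c(-c5ncc(Cl)cn5)n(C)c4c3)CCC2)ccc1/C=C/C(=O)OCC(=O)N1CCCC1` is not yet measured. It differs from compound 3 by (pyrrolidin-1-yl)carbonyl in place of (2-methoxyethoxy)methyl on a saturated chain carbon bound to an oxygen next to a carbonyl group. The measured steps that bear on this place are an at least 5.8-fold lower number from compound 2 to compound 3 (0.76 log units; beyond the scatter) and an at least 5.8-fold lower number from compound 1 to compound 3 (0.76 log units; beyond the scatter); both show that bringing the 2-methoxyethoxy chain into the ester tail shortened the half-life beyond the scatter. Among the measured compounds shown here, compound 4 removes that chain again, so a longer half-life than that of compound 3 is expected, although the entering (pyrrolidin-1-yl)carbonyl group has no precedent in this set and a return to the limit is not assured. The expected step from compound 3 to compound 4 is a 2.9-fold higher number from compound 3 to compound 4 (0.47 log units; beyond the scatter). For compound 4 the estimate in this assay is 2.5 h, with a range from 0.9 h to 6 h.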

Compound 4, half-life: 1.65 h
Estimate against measurement, compound 4: 1.5-fold (0.18 log units) above; the range from low to high includes it.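

In this assay, a 1.9-fold higher number from compound 3 to compound 4 (0.29 log units; within the scatter), so compound 3 and compound 4 are not separated, although (pyrrolidin-1-yl)carbonyl replaces (2-methoxyethoxy)methyl on the saturated chain carbon bound to an oxygen next to a carbonyl group. Removing the 2-methoxyethoxy chain is therefore not enough to recover the behaviour of the two simpler esters, as the new tail also falls short of them, with an at least 3.0-fold lower number from compound 2 to compound 4 (0.48 log units; beyond the scatter) and an at least 3.0-fold lower number from compound 1 to compound 4 (0.48 log units; beyond the scatter); within these four compounds, the shorter half-life is not tied to the 2-methoxyethoxy chain alone. These two steps give only a lower bound on size because compound 1 and compound 2 both stand at a limit of the assay: the limit of > 5 h in this assay, at which 2 of the 4 values shown sit.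

As far as these compounds go, it remains open whether the pyrrolidine ring, the amide carbonyl or the overall length of the tail governs the result, which a dimethylamide, a morpholine amide or a plain hexyl chain at this carbon could help separate. The free carboxylic acid in place of the ester also lies outside the compounds shown, so the role of the ester itself in this read-out remains untested.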